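A few compounds are considered here, and "the series" means these few. Any claim that something is new, unique, unknown or untested is made for them only; others in the source may bear on it.

Measured in a functional assay on HT-29 cells (Homo sapiens) for cytotoxicity, read by sulforhodamine B assay; a lower number here means that less compound is tolerated, a higher number that more compound is tolerated:
- Compound 1 `COC1=C(Br)[C@H](O)[C@@]2(C=C1Br)CC(C(=O)NCCCCCNC(=O)C1=NO[C@]3(C=C(Br)C(=O)[C@@H](Br)[C@@H]3O)C1)=NO2`: 9100 nM
- Compound 2 `COC1=C(Br)[C@H](O)[C@@]2(C=C1Br)CC(C(=O)NCCCCNC(=O)C1=NO[C@]3(C=C(Br)C(=O)[C@@H](Br)[C@@H]3O)C1)=NO2`: 11300 nM
- Compound 3 `O=C(NCCCCCNC(=O)C1=NO[C@]2(C=C(Br)C(=O)[C@H](Br)[C@@H]2O)C1)C1=NO[C@]2(C=C(Br)C(=O)[C@H](Br)[C@@H]2O)C1`: 3700 nM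

Compound 2 and compound 1 lie within the scatter of each other, at the upper end of these three numbers. Compound 3 sits below compound 2, and that gap is beyond the scatter.

Compound 4 `COC1=C(Br)[C@H](O)[C@@]2(C=C1Br)CC(C(=O)NCCCCNC(=O)C1=NO[C@]3(C=C(Br)C(=O)[C@H](Br)[C@@H]3O)C1)=NO2` has not yet been measured. It has the same atoms and bonds as compound 2 and differs only in configuration as drawn (the two compounds have the same atoms and bonds and differ only in configuration as drawn: 1 of 5 stereo elements differ; a stereocentre at a saturated ring carbon is drawn S in compound 2 and R in compound 4): a stereocentre at a saturated ring carbon is drawn S in compound 2 and R in compound 4. Within the data shown here, no measured pair isolates such a change, so the evidence is thin. Among the measured compounds shown here, the one hint is compound 3 at 3700 nM, which shares the drawing of compound 4 at this carbon but also differs from it elsewhere. A small downward shift, within the scatter, is therefore expected: a 1.6-fold lower number from compound 2 to compound 4 (0.21 log units; within the scatter). The estimated value for compound 4 is 7000 nM, with an expected range from 3000 nM to 14000 nM.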

Compound 4, concentration lethal to 50% of the cells: 8500 nM
Compound 4: middle estimate off by 1.2-fold (0.08 log units), on the low side, within the range that was stated.
By their numbers in this assay, from the lowest: compound 3; then compounds 4, 1 and 2 (each within the scatter of the next).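

Among these compounds, this pair gives the first clean reading of a single change in the set, and what makes it clean is this: the fact that compounds 2 and 4 differ only in the configuration as drawn. In this assay, redrawing the stereocentre at a saturated ring carbon from S to R gives a 1.3-fold lower number from compound 2 to compound 4 (0.12 log units; within the scatter), so at this carbon the two configurations cannot be told apart by their numbers. Within this pair, the configuration at this one carbon therefore shows no measurable effect on how much compound the cells tolerate.

On these data alone, the other four stereo elements remain untested on their own, and it remains open whether this carbon would behave the same way with a different chain joining the two halves. Also open, as far as these compounds go, is what an amine or a carboxylic acid at this carbon, in place of the bromine, would do to the number.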